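Adding methoxy to compound 3

The source may hold more compounds than are shown below. What is called first, only, known or untested is meant among the compounds shown, and "the series" means these compounds.

Compound 1 `COc1ccc(-c2nc3sc(-c4ccccc4)cn3n2)cc1` gives 56%
Compound 2 `COc1cc(-c2nc3sc(-c4ccccc4)cn3n2)cc(OC)c1OC` gives 29%
Compound 3 `Clc1ccc(-c2cn3nc(-c4ccccc4)nc3s2)cc1` gives 52%

In a functional assay on A498 cells (Homo sapiens) for inhibition, read by sulforhodamine B assay, with a stated time of 48 h, tested at 10 uM (a higher number here means more inhibition of growth at the concentration tested, a lower number less inhibition of growth), compound 3 gives 52% and cannot be told apart from compound 1, while it lies clearly higher than compound 2. Compound 4 `COc1ccc(-c2nc3sc(-c4ccc(Cl)cc4)cn3n2)cc1` has not been measured yet. The change methoxy in place of hydrogen on an aromatic carbon puts methoxy in place of hydrogen on an aromatic carbon, para to a large group. Within the data shown here, no two tested compounds differ in one place only, so no measured step guides this change. Compound 1 carries methoxy and gives 56% while compound 2, also with methoxy, gives 29% so the range stays wide. The estimated step of a number 2 percentage points higher from compound 3 to compound 4 (within the scatter) is expected to stay within the scatter, with no clear direction. Compound 4 is estimated at 54% with 34% to 72% as its expected range.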

Compound 4, percent growth inhibition at one concentration: -25.8%
Estimate against measurement, compound 4: 79.8 percentage points above; the measured number lies below the stated range.
By their numbers in this assay, from the lowest: compound 4; then compound 2; then compounds 3 and 1 (each within the scatter of the next).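

Methoxy in place of hydrogen on an aromatic carbon, para to a large group, proves far from neutral in this assay: it gives a number 77.8 percentage points lower from compound 3 to compound 4 (beyond the scatter). The step from the other side, chloro in place of hydrogen on an aromatic carbon, gives a number 81.8 percentage points lower from compound 1 to compound 4 (beyond the scatter), so a large fall appears whichever group enters last, and each group's effect depends on the other being present. Nothing shown explains this fall.

From the compounds shown here alone, whether an amine or a hydroxy group at this place, with the chloro kept, would also lower the number stays open. So does whether the same holds for an ethoxy group.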